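The source may hold more compounds than are shown below. What is called first, only, known or untested is meant among the compounds shown, and "the series" means these compounds.

Of the compounds shown here, two have been measured in a functional assay on HT-29 cells (Homo sapiens) for inhibition, read by MTT assay, with a stated time of 72 h; on this read-out lower numbers stand for stronger inhibition and higher numbers for weaker inhibition. Compound 1, with the structure `COc1cc2c(Oc3ccc(NC(=O)c4nn(-c5cccc(F)c5)c(=O)cc4C)cc3F)ccnc2cc1OCCCN1CCCCC1`, gives 290 nM. Compound 2, with the structure `COc1ccc(-n2nc(C(=O)Nc3ccc(Oc4ccnc5cc(OCCCN6CCCC6)c(OC)cc45)c(F)c3)c(C)cc2=O)cc1`, gives 3300 nM. Compound 2 therefore stands with the higher of the two numbers, and the gap to compound 1 is beyond the usual scatter, so compound 1 is the stronger inhibitor of the pair. Compound 1 and compound 2 differ in more than one place, so no single change can be held responsible for that gap.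

Compound 3, with the structure `COc1ccc(-n2nc(C(=O)Nc3ccc(Oc4ccnc5cc(OCCCN6CCCCC6)c(OC)cc45)c(F)c3)c(C)cc2=O)cc1`, has not yet been measured. It differs from compound 2 in one place only: piperidin-1-yl in place of pyrrolidin-1-yl on a saturated chain carbon, three bonds along the chain from an oxygen on an aromatic ring. The change sits at the end of the three-carbon chain attached through an oxygen to the aromatic core, far from the amide and the pyridazinone that compound 2 and compound 3 share. Compound 1 also carries a piperidin-1-yl at that end of the chain, but it differs from compound 2 elsewhere too, so it gives only a loose hint. The step from compound 2 to compound 3 is expected to be small, near the scatter, and if anything toward a lower number, as a 1.7-fold lower number from compound 2 to compound 3 (0.22 log units; within the scatter). Compound 3 is estimated at 2000 nM, with a plausible range from 700 nM to 6000 nM.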

Compound 3, half-maximal inhibitory concentration: 3200 nM
Compound 3: the middle estimate sits 1.6-fold (0.20 log units) below what was measured; low and high end bracket the measured number.
By their numbers in this assay, from the lowest: compound 1; then compounds 3 and 2 (each within the scatter of the next).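

In this assay, piperidin-1-yl in place of pyrrolidin-1-yl on a saturated chain carbon, three bonds along the chain from an oxygen on an aromatic ring, gives a 1.0-fold lower number from compound 2 to compound 3 (0.01 log units; within the scatter), so with 4-methoxyphenyl on the aromatic nitrogen, this change at the end of the chain does not alter the read-out beyond normal assay variation. Going by these compounds alone, compound 3 also forms the first single-change pair with compound 1, and 4-methoxyphenyl in place of 3-fluorophenyl on an aromatic nitrogen gives an 11-fold higher number from compound 1 to compound 3 (1.04 log units; beyond the scatter), a large step beyond the scatter. Among these three compounds, the large difference therefore follows the group on the aromatic nitrogen and not the ring at the end of the chain, although no supporting data are available to explain either result.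

As far as these compounds go, it remains open whether the end of the chain would stay this insensitive with 3-fluorophenyl on the aromatic nitrogen, a question that pyrrolidin-1-yl paired with that group could address. The compounds shown also leave open how a morpholin-4-yl ring, an open-chain dimethylamino group or a longer chain would compare at this position.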